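The source may hold more compounds than are shown below. What is called first, only, known or untested is meant among the compounds shown, and "the series" means these compounds.

Compound 1: `ClCc1ccccc1Cn1cnc2c(Cl)ncnc21` — 1820 nM
Compound 2: `ClCc1cccc(Cn2cnc3c(Cl)ncnc32)c1` — 1540 nM

Of the compounds shown here, two have been measured so far. In a functional assay on CAKI-1 cells (Homo sapiens) for cytotoxicity, read by sulforhodamine B assay, with a stated time of 48 h (a lower number here means a stronger inhibitor of growth, a higher number a weaker inhibitor of growth), compound 1 gives 1820 nM, and compound 2 gives 1540 nM. Compound 2 has the lower of the two numbers, but the gap between it and compound 1 lies within the usual scatter of such measurements, so the two cannot be told apart on these data.

The next compound is compound 3, `ClCc1cccc(Cn2cnc3c(Cl)nc(Cl)nc32)c1`. It differs from compound 2 in one place: chloro in place of hydrogen on an aromatic carbon. Among the compounds with values here, no pair of measured compounds shows what this particular change does, so there is no measured step to lean on.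

Within the data shown here, with nothing to go by but the shared core and the single added chloro group, the expected outcome is a small step, one that may well stay within the scatter, leaning slightly toward a lower number in this assay. The step from compound 2 to compound 3 is estimated as a 1.3-fold lower number from compound 2 to compound 3 (0.11 log units; within the scatter). On that basis compound 3 is expected to give about 1200 nM in this assay, with a plausible range from 400 nM to 3600 nM.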

Compound 3, concentration for 50% growth inhibition: 2230 nM
The estimate for compound 3 lay 1.9-fold (0.27 log units) below the measured number, within the range that was stated.
By their numbers in this assay, from the lowest: compounds 2, 1 and 3 (each within the scatter of the next).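

Replacing hydrogen with a chloro group on the aromatic carbon between two ring nitrogen atoms gives a 1.4-fold higher number from compound 2 to compound 3 (0.16 log units; within the scatter) in this assay. Within the data shown here, this is the first measured look at this change, and it shows that a single added chlorine at this position leaves the number indistinguishable from that of compound 2, so this position can carry a chloro group without a step that can be told from the scatter. No other measurement is available that could explain this result or show what the added chlorine does to the compound in cells.

The compounds shown leave open whether a different group at this same carbon, such as an amine, a methoxy group or a longer chain, would give a step beyond the scatter, since one small group at one position says little about larger or differently built ones. Also open, as far as these compounds go, is what happens when the chloro group that stands meta to this position, present in all three compounds, is replaced by an amine, and whether the chloro change would give the same small step on compound 1.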